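Swapping tert-butyl for ethyl on compound 1

The source may report more compounds than this note shows. Statements on the series, on what has been measured and on what is new or still open speak of the compounds shown alone.

Among the compounds with values here, in a physicochemical assay for solubility, at pH 7.4 (a higher number here means a more soluble compound, a lower number a less soluble compound), compound 1 `Cc1cc(NC(=O)Nc2ccc(C(C)(C)C)cc2)c2ccccc2n1` gives 6200 nM, the higher of the two numbers so far. Compound 2 `Cc1cc(NC(=O)Nc2ccc(C)c(Cl)c2)c2ccccc2n1` gives 300 nM, lower by more than the usual scatter. Compound 3 `CCc1ccc(NC(=O)Nc2cc(C)nc3ccccc23)cc1` keeps the core of compound 1 but has ethyl in place of tert-butyl on an aromatic carbon. Within the data shown here, no measured pair shows this change alone, so any forecast is loose. A moderate fall, just beyond the scatter, is expected, an estimated step of a 3.1-fold lower number from compound 1 to compound 3 (0.49 log units; beyond the scatter). For compound 3, the estimated value is 2000 nM, with an expected range of 400 nM to 9000 nM.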

Compound 3, solubility: 3300 nM
The estimate for compound 3 lay 1.7-fold (0.22 log units) below the measured number; low and high end bracket the measured number.
By their numbers in this assay, from the lowest: compound 2; then compounds 3 and 1 (each within the scatter of the next).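

In this assay the step of a 1.9-fold lower number from compound 1 to compound 3 (0.27 log units; within the scatter) shows that ethyl in place of tert-butyl, on an aromatic carbon para to a large group, leaves the two compounds indistinguishable. At this position, then, going from 4 heavy atoms to 2 gives no change that can be read on this core. Nothing at hand explains this result.

As far as these compounds go, whether an amine, a carboxylic acid or a longer chain at the same position would also hold the number stays open. So does whether this swap behaves the same way on other compounds.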